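This account rests on a few compounds, and the source may have more. Where it says the series, first, only, none or still open, it means among the compounds named here.

Compound 1 `O=C1N(CCCCCCOc2ccc(C(F)(F)F)cc2)CCN1c1ccncc1` is one of three close relatives tested in a functional assay on cells (Homo sapiens) for cytotoxicity; a higher number here means that more compound is tolerated, a lower number that less compound is tolerated. In this assay compound 1 gives > 25000 nM, which is a limit of the assay rather than a measured number. Compound 2 `O=C1N(CCCCCCOc2ccc(Cl)cc2)CCN1c1ccncc1` differs from it only at the aryl ether end, where chloro replaces trifluoromethyl. In this assay compound 2 gives > 25000 nM, again a limit. Compound 3 `Cc1ccc(OCCCCCCN2CCN(c3ccncc3)C2=O)cc1` carries methyl in that place. In this assay compound 3 gives > 25000 nM, a limit as well. The three measured steps are therefore a step that the two limits leave unreadable from compound 1 to compound 2, a step that the two limits leave unreadable from compound 1 to compound 3 and a step that the two limits leave unreadable from compound 2 to compound 3, none of which can be sized; the reason is the limit of > 25000 nM in this assay, at which 3 of the 3 values shown sit.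

Compound 4 `O=C1N(CCCCCCOc2ccc(C(F)(F)F)cc2)CCN1c1ccnc(Cl)c1` alters the opposite end of compound 1 instead: chloro in place of hydrogen on an aromatic carbon. Among the measured compounds shown here, no measured step touches this part of the molecule, and the three steps that exist all concern the aryl ether group and are unreadable, so nothing about them points in either direction. With every relative sitting at the limit, the expectation for compound 4 rests on that alone. Compound 4 is thus expected to give about 30000 nM, most likely between 8000 nM and 100000 nM. The estimated step that the limit leaves unreadable from compound 1 to compound 4 is expected to be none beyond the scatter, with a good chance that only a limit is reported again.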

Compound 4, half-maximal cytotoxic concentration: > 25000 nM
Compound 4: a limit, no number (the forecaster's own chance of this, stated with the estimate: 70%); the middle value does not contradict the limit.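

The step from compound 1 to compound 4, where chloro replaces hydrogen, cannot be read, because neither compound gives a number in this assay: the limit of > 25000 nM in this assay, at which 4 of the 4 values shown sit.

The compounds shown leave open at what concentration any of them harms cells, and whether changing either end of the molecule affects how much is tolerated.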